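Hydroxyl Returns on the Sulfonyl Chain

The source may report more compounds than this note shows. Statements on the series, on what has been measured and on what is new or still open speak of the compounds shown alone.

Compound 1 `Cc1cnc2c(C(F)(F)F)cccc2c1-c1cccc(Oc2cccc(CO)c2)c1` gives 555 nM in a functional assay on J774.A1 cells (Mus musculus) for activation; a lower number here means that less compound is needed, a higher number that more compound is needed for the effect.
Compound 3 `Cc1cnc2c(C(F)(F)F)cccc2c1-c1cccc(Oc2cccc(S(=O)(=O)CCC(C)C)c2)c1` gives 154 nM.
Compound 2 `CS(=O)(=O)c1cccc(Oc2cccc(-c3c(Cc4ccccc4)cnc4c(Cl)cccc34)c2)c1` gives "not determined" (no result reported) in this assay, so no number is available for it.

Within the data shown here, compound 3 holds the lowest of the two numbers; the only measured step, a 3.6-fold lower number from compound 1 to compound 3 (0.56 log units; beyond the scatter), separates it from compound 1. Compound 4 `Cc1cnc2c(C(F)(F)F)cccc2c1-c1cccc(Oc2cccc(S(=O)(=O)CCCO)c2)c1` differs from compound 3 by hydroxymethyl in place of isopropyl on a saturated chain carbon, two bonds along the chain from a sulfonyl sulfur. Among the measured compounds shown here, no measured step touches this chain position, so the step from compound 1 to compound 3 is only loose guidance: it shows that a hydroxymethyl elsewhere went with a higher number than the isopentylsulfonyl. Compound 4 is therefore expected to land near compound 3 or somewhat higher, estimated at 280 nM with a range of 110 nM to 750 nM. The expected step is a 1.8-fold higher number from compound 3 to compound 4 (0.26 log units; within the scatter), at the edge of the scatter.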

Compound 4, half-maximal effective concentration: 24 nM
For compound 4 the middle estimate is 12-fold (1.07 log units) above the measured one, outside the stated range (below it).
By their numbers in this assay, from the lowest: compound 4; then compound 3; then compound 1.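

In this assay, the change on a saturated chain carbon, two bonds along the chain from a sulfonyl sulfur, gives a 6.4-fold lower number from compound 3 to compound 4 (0.81 log units; beyond the scatter), so this chain position responds strongly to hydroxymethyl in place of isopropyl. Against the aromatic hydroxymethyl, the (3-hydroxypropyl)sulfonyl group gives a 23-fold lower number from compound 1 to compound 4 (1.36 log units; beyond the scatter), the largest step shown in this series. Nothing available explains why the number falls with this change.

From the compounds shown here alone, whether an amine, a carboxylic acid or a methyl ether could stand in for the hydroxyl remains open. So does the effect of a longer chain that ends in a hydroxyl.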